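Replacing 4-nitrobenzyl with pentyl: notes on compound 3

The source may hold more compounds than are shown below. What is called first, only, known or untested is meant among the compounds shown, and "the series" means these compounds.

Values in a functional assay on A549 cells (Homo sapiens) for antiproliferative activity, read by MTT assay; on this read-out lower numbers stand for stronger inhibition and higher numbers for weaker inhibition:
- compound 1 `CC1(C)CCc2cc(C(=O)/C=C/c3ccc(OCc4cn(-c5ccc(Cl)cc5)nn4)cc3)c(O)cc2O1` gives 75500 nM
- compound 2 `CC1(C)CCc2cc(C(=O)/C=C/c3ccc(OCc4cn(Cc5ccc([N+](=O)[O-])cc5)nn4)cc3)c(O)cc2O1` gives 35800 nM

Of the two values, that of compound 2 is the lower. Compound 3 `CCCCCn1cc(COc2ccc(/C=C/C(=O)c3cc4c(cc3O)OC(C)(C)CC4)cc2)nn1` is still unmeasured. Its change from compound 2 is butyl in place of 4-nitrophenyl on a saturated chain carbon bound to an aromatic nitrogen; cut one bond further out, this reads 4-nitrobenzyl to pentyl. Within the data shown here, the only measured step, a 2.1-fold lower number from compound 1 to compound 2 (0.32 log units; beyond the scatter), was modest and also involved the group on an aromatic nitrogen, but it offers only indirect guidance. A small rise in this assay, not clearly beyond the scatter, is therefore expected. The estimated change is a 1.5-fold higher number from compound 2 to compound 3 (0.19 log units; within the scatter). For compound 3 the expected value is 55000 nM, with an estimated range of 20000 nM to 120000 nM.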

Compound 3, half-maximal inhibitory concentration: 91300 nM
Compound 3: the middle estimate sits 1.7-fold (0.22 log units) below what was measured, and the stated range covers the measured number.
By their numbers in this assay, from the lowest: compound 2; then compounds 1 and 3 (each within the scatter of the next).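

In this assay, butyl in place of 4-nitrophenyl on a saturated chain carbon bound to an aromatic nitrogen gives a 2.6-fold higher number from compound 2 to compound 3 (0.41 log units; beyond the scatter), so pentyl does not hold the level of 4-nitrobenzyl. Pentyl in place of 4-chlorophenyl on an aromatic nitrogen gives a 1.2-fold higher number from compound 1 to compound 3 (0.08 log units; within the scatter), which leaves these two groups level and compound 2 alone in the series. No available evidence accounts for either step.

On these data alone, it remains open whether the difference tracks the nitro group or the benzyl group as a whole. A 4-chlorobenzyl group on the same nitrogen would separate the two.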